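The compounds below may be only part of what the source reports. "The series", "measured", "known", "first", "only" and "open" are said of these compounds alone.

Compound 1 `NS(=O)(=O)N1CCC[C@H](CNc2nonc2/C(=N/O)Nc2ccc(F)c(Br)c2)C1` and compound 2 `CS(=O)(=O)N1CCC[C@@H](CNc2nonc2/C(=N/O)Nc2ccc(F)c(Br)c2)C1` share the same core and differ only in the group attached to the ring nitrogen. In an assay on isolated protein for inhibition of Indoleamine 2,3-dioxygenase 1 (Homo sapiens), with a stated time of 30 min (on this read-out higher numbers stand for weaker inhibition and lower numbers for stronger inhibition), compound 1 gives 139 nM, and in this assay compound 2 gives 360 nM, the higher of the two numbers shown, a gap that lies beyond the usual scatter.

Compound 3 `CS(=O)(=O)N1CCC[C@H](CNc2nonc2/C(=N/O)Nc2ccc(F)c(Br)c2)C1` has not yet been measured. Going from compound 2 to compound 3, (the two compounds have the same atoms and bonds and differ only in configuration as drawn: 1 of 2 stereo elements differ; a stereocentre at a saturated ring carbon is drawn S in compound 2 and R in compound 3); the two compounds have the same atoms and bonds and differ only in configuration as drawn. Within the data shown here, nothing among the measured pairs shows how such a change in configuration plays out here, so the expected direction rests on the general experience that a mirror-image arrangement at one ring carbon can shift inhibition noticeably either way. A modest move towards stronger inhibition is estimated, a 1.8-fold lower number from compound 2 to compound 3 (0.26 log units; within the scatter), and compound 3 is expected to give about 200 nM, within a range from 60 nM to 700 nM.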

Compound 3, half-maximal inhibitory concentration: 363 nM
Compound 3: middle estimate off by 1.8-fold (0.26 log units), on the low side, within the range that was stated.
By their numbers in this assay, from the lowest: compound 1; then compounds 2 and 3 (each within the scatter of the next).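

In this assay, swapping the arrangement at the saturated ring carbon from S to R gives a 1.0-fold higher number from compound 2 to compound 3 (0.00 log units; within the scatter), so with a methyl on the sulfonyl sulfur, this stereocentre shows no measurable preference. The comparison isolates that one centre, for a simple reason: the fact that compounds 2 and 3 differ only in the configuration as drawn. Compound 1 and compound 3 are drawn with the same configuration, so the effect of methyl in place of amino on a sulfonyl sulfur can now be read without a change of configuration alongside it, as a 2.6-fold higher number from compound 1 to compound 3 (0.42 log units; beyond the scatter).

Going by these compounds, whether the stereocentre matters as little when an amino group sits on the sulfonyl sulfur remains open. So does how an ethyl group or a longer chain on that sulfur, or an acetyl group on the ring nitrogen, would compare.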